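Methoxy to Hydroxy: An Expectation for Compound 3

The compounds below may be only part of what the source reports. "The series", "measured", "known", "first", "only" and "open" are said of these compounds alone.

Of the compounds shown here, two have been measured in a functional assay on UACC-257 cells (Homo sapiens) for cytotoxicity, read by sulforhodamine B assay, with a stated time of 48 h, tested at 100 nM; on this read-out lower numbers stand for a stronger effect and higher numbers for a weaker effect at the one concentration tested. Compound 1 `Cc1cc(O)cc(-c2nn(CC#N)cc2-c2ccnc(-c3ccc(Oc4ccccc4)cc3)c2)c1` gives 84% in this assay. Compound 2 `COc1cc(C)cc(-c2nn(CC#N)cc2-c2ccnc(-c3ccc(N(C)C)cc3)c2)c1` gives 28% in this assay, the lowest of the two numbers, and its distance from the number of compound 1 lies beyond the scatter. Among the measured compounds shown here, compound 1 and compound 2 differ in more than one place, so no single-point step between measured compounds is available, and the gap between their two values cannot be tied to one change.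

Compound 3 `Cc1cc(O)cc(-c2nn(CC#N)cc2-c2ccnc(-c3ccc(N(C)C)cc3)c2)c1` has not yet been measured. It differs from compound 2 by hydrogen in place of methyl on an oxygen on an aromatic ring; cut one bond further out, the same difference reads methoxy to hydroxy, or 3-methoxy-5-methylphenyl to 3-hydroxy-5-methylphenyl. Compound 3 shares one part of its structure with compound 1 and the rest with compound 2, so the two measured numbers bracket the possibilities without settling them. The expected step in this assay is a number 14 percentage points higher from compound 2 to compound 3 (beyond the scatter), a modest rise that may not clear the scatter. The estimate for compound 3 in this assay is 42%, within a range from 18% to 78%.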

Compound 3, a percentage reported as activity, at one concentration (the size of the read-out at that concentration, not a potency): 83%
Beside the measured number, compound 3's estimate is 41 percentage points below it, outside the stated range (above it).
By their numbers in this assay, from the lowest: compound 2; then compounds 3 and 1 (each within the scatter of the next).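

In this assay, hydrogen in place of methyl on an oxygen on an aromatic ring gives a number 55 percentage points higher from compound 2 to compound 3 (beyond the scatter), so this single change, with the dimethylamino group kept, is enough to produce a large loss of effect at the one concentration tested, something the earlier pair, differing in more than one place, could not show. With the hydroxy group kept, dimethylamino in place of phenoxy on an aromatic carbon gives a number 1 percentage points lower from compound 1 to compound 3 (within the scatter), so of the two changes that separate compound 1 from compound 2, only methoxy to hydroxy is seen here as a step beyond the scatter. No measurement is available that bears on why removing this methyl has so large an effect.

The compounds shown leave open whether dimethylamino and phenoxy would also stay within the scatter of each other with a methoxy group on that oxygen, since the phenoxy step has been read only with hydroxy present. They also leave open how an ethoxy group, a longer alkoxy chain or an amine in that same place would read on this scale.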